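From fluoro to trifluoromethoxy on a shared core

The source may hold more compounds than are shown below. What is called first, only, known or untested is meant among the compounds shown, and "the series" means these compounds.

Compound 1 `CC(O)(CSc1ccc(S(F)(F)(F)(F)F)cc1)C(=O)Nc1cccc(S(F)(F)(F)(F)F)c1` gives 24100 nM
Compound 2 `CC(O)(CSc1ccc(F)cc1)C(=O)Nc1cccc(S(F)(F)(F)(F)F)c1` gives 21900 nM
Compound 3 `CC(O)(CSc1cccc(C(F)(F)F)c1)C(=O)Nc1cccc(S(F)(F)(F)(F)F)c1` gives 20200 nM

In a functional assay on VCaP cells (Homo sapiens) for antiproliferative activity, read by propidium iodide staining, with a stated time of 96 h (on this read-out lower numbers stand for stronger inhibition and higher numbers for weaker inhibition), compound 2 gives 21900 nM and sits in one tight group with the other two compounds, with no order among them that the data can support. Compound 4 `CC(O)(CSc1ccc(OC(F)(F)F)cc1)C(=O)Nc1cccc(S(F)(F)(F)(F)F)c1` carries a single change from compound 2: trifluoromethoxy in place of fluoro on an aromatic carbon, para to a large group.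

Within the data shown here, two measured steps bear on this change. Compound 1 holds a larger group on the same aromatic carbon, and replacing it with fluorine gives a 1.1-fold lower number from compound 1 to compound 2 (0.04 log units; within the scatter) as the step. Placing 3-(trifluoromethyl)phenyl in place of 4-fluorophenyl on a sulfur gives a 1.1-fold lower number from compound 2 to compound 3 (0.04 log units; within the scatter) as the step. Neither exceeds the scatter, so no shift beyond the scatter is expected in this assay here, though three compounds are a thin basis. The expected step is a 1.0-fold lower number from compound 2 to compound 4 (0.02 log units; within the scatter) and no more. The estimate for compound 4 is 21000 nM, with an expected range from 12000 nM to 35000 nM for the coming measurement.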

Compound 4, half-maximal inhibitory concentration: 28500 nM
Estimate against measurement, compound 4: 1.4-fold (0.13 log units) below; the measured number falls inside the stated range.
By their numbers in this assay, from the lowest: compounds 3, 2, 1 and 4 (each within the scatter of the next).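

In this assay, trifluoromethoxy on this aromatic carbon, para to a large group, reads the same as the fluoro it replaces (a 1.3-fold higher number from compound 2 to compound 4 (0.11 log units; within the scatter)) and the same as the larger group of compound 1 (a 1.2-fold higher number from compound 1 to compound 4 (0.07 log units; within the scatter)). The earlier compounds had shown only two groups at this place; a third, which brings in oxygen and carbon, stays in the same tight group, so groups of quite different atom counts here leave the number within the scatter. No measurement available gives a reason for this flat result.

On these data alone, whether an amine or a carboxylic acid on this aromatic carbon would stay in that group remains open. So does whether any group here can move the number beyond the scatter, on this core or on one with the hydroxyl replaced.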